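The compounds below may be only part of what the source reports. "The series", "measured", "known", "first", "only" and "open" are said of these compounds alone.

Working notes on the series.

Three compounds of the series carry numbers in an ADME assay on microsomes from liver (Homo sapiens) for metabolic stability, read by LC-MS, using NADPH, with a stated time of 10 min, tested at 0.5 uM; on this read-out higher numbers stand for a more stable compound and lower numbers for a less stable compound. Compound 1 `COC(=O)Nc1cc(-c2ccc(OC[C@@](C)(N)CC(C)C)c(C)c2)ccn1` gives 98%. Compound 2 `Cc1cc(-c2cc(Cl)c(OC[C@@](C)(N)CC(C)C)cn2)ccn1` gives 86%. Compound 3 `COC(=O)Nc1cc(-c2cnc(OC[C@@](C)(N)CC(C)C)c(OC)c2)ccn1` gives 86%. On these numbers compound 3 stands level with compound 2 at the digits read, the two together being the lowest of the three; its nearest neighbour is compound 2, with no change at the digits read and within the scatter, and its furthest is compound 1, whose number lies higher by a margin beyond the scatter. For the measured compounds named here, no two of the measured compounds differ in one place only, so no single step can be drawn from them.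

Compound 4 `COC(=O)Nc1cc(-c2cnc(OC[C@@](C)(N)CC(C)C)c(Cl)c2)ccn1` is the next compound to be run in this assay. It differs from compound 3 in one place: chloro in place of methoxy on an aromatic carbon.

The step of no change at the digits printed from compound 3 to compound 4 (within the scatter) is expected to stay within the scatter, with no direction beyond it, because compound 2 gives 86% while already carrying a chloro on its own core. Compound 4 is therefore estimated at 86% in this assay, expected between 72% and 96%.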

Compound 4, percent of the compound remaining: 90%
For compound 4 the middle estimate is 4 percentage points below the measured one; measured number inside the range.
By their numbers in this assay, from the lowest: compounds 2, 3, 4 and 1 (each within the scatter of the next, the first and the last beyond it).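

Chloro in place of methoxy on this aromatic carbon, ortho to a (2-amino-2,4-dimethylpentyl)oxy group and two atoms from the ring nitrogen, gives a number 4 percentage points higher from compound 3 to compound 4 (within the scatter) in this assay. For the compounds shown here, this is the first one-place comparison, and it shows that at this position the read-out does not separate the two groups, even though the hydrogen-bond acceptor of methoxy leaves with the change. Nothing measured bears on why the two groups read alike.

Going by these compounds, whether an amine, a carboxylic acid or a longer chain such as propoxy on this aromatic carbon would also stay within the scatter remains open. Also open, on these data alone, is whether the same change would read alike on the core of compound 1 or of compound 2.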